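Swapping a pyrrolidine for a morpholine on a thiourea

This account rests on a few compounds, and the source may have more. Where it says the series, first, only, none or still open, it means among the compounds named here.

Measured so far, in a functional assay on A-431 cells (Homo sapiens) for cytotoxicity, read by MTT assay, with a stated time of 72 h; a lower number here means a stronger inhibitor, a higher number a weaker inhibitor:
Compound 1 `N/C(=N\NC(=S)N1CCCC1)c1ccc(F)cn1` gives 1000 nM.
Compound 2 `Cc1cccc(/C(N)=N/NC(=S)N2CCOCC2)n1` gives 4300 nM.
Compound 3 `Cc1cccc(/C(N)=N/NC(=S)N2CCCC2)n1` gives 4000 nM.

Compound 1 has the lowest number of the three, and its gap to compound 3 and compound 2 lies beyond the scatter in both cases. The step to compound 4 `N/C(=N\NC(=S)N1CCOCC1)c1ccc(F)cn1` is morpholin-4-yl in place of pyrrolidin-1-yl on a thiocarbonyl carbon. For the measured compounds named here, only one measured step bears on it, and it runs in the opposite direction: a 1.1-fold lower number from compound 2 to compound 3 (0.03 log units; within the scatter), a change within the scatter. Turning that step around, the same exchange on the core of compound 1 is expected to leave the number essentially unchanged, so compound 4 is expected at 1100 nM, within 500 nM to 2500 nM, a step of a 1.1-fold higher number from compound 1 to compound 4 (0.04 log units; within the scatter).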

Compound 4, half-maximal inhibitory concentration: 4000 nM
Beside the measured number, compound 4's estimate is 3.6-fold (0.56 log units) below it, and the stated range ends below it.
By their numbers in this assay, from the lowest: compound 1; then compounds 3, 4 and 2 (each within the scatter of the next).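

Morpholin-4-yl in place of pyrrolidin-1-yl on a thiocarbonyl carbon now carries a clear cost in this assay, with a 4.0-fold higher number from compound 1 to compound 4 (0.60 log units; beyond the scatter). The earlier pair gave no sign of this, and the same exchange does not have the same size on the two cores: the same change on two cores in this assay, a 1.1-fold lower number (0.03 log units; within the scatter) from compound 2 to compound 3 and a 4.0-fold lower number (0.60 log units; beyond the scatter) from compound 4 to compound 1, 3.7-fold (0.57 log units) apart, beyond the scatter of two such steps. What this exchange does therefore depends on the core that carries it, at least across the two cores shown.

Still open, as far as these compounds go, is whether piperidin-1-yl or a dimethylamino group at this place would keep the number of compound 1 or lose it as compound 4 does.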